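Aryl for Cycloalkyl on a Thiourea Nitrogen

This account rests on a few compounds, and the source may have more. Where it says the series, first, only, none or still open, it means among the compounds named here.

Compound 1 `CC1CN(C(N)=S)N=C1c1ccccc1`: > 100000 nM
Compound 2 `CC1CN(C(=S)NC2CCCCC2)N=C1c1ccccc1`: > 100000 nM

Both measured values come from an ADME assay on KB cells (Homo sapiens) for cytotoxicity, read by MTT assay, with a stated time of 44 h; on this read-out lower numbers stand for stronger inhibition and higher numbers for weaker inhibition. In this assay compound 1 gives only a limit, > 100000 nM. In this assay compound 2 likewise gives only a limit, > 100000 nM. The step from compound 1 to compound 2, cyclohexyl in place of hydrogen on an amide-type nitrogen, is a step that the two limits leave unreadable from compound 1 to compound 2. Compound 2 therefore stands at the limit described by the limit of > 100000 nM in this assay, at which 2 of the 2 values shown sit, and nothing places it more precisely.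

Compound 3 `Cc1ccccc1NC(=S)N1CC(C)C(c2ccccc2)=N1` differs from compound 2 by 2-methylphenyl in place of cyclohexyl on an amide-type nitrogen. For the measured compounds named here, no measured step involves an aromatic group at this position, and the only step that alters this nitrogen gives no readable size, so no direction can be drawn from it. Compound 3 is therefore expected to remain near the limit, with an assumed step of a number no higher from compound 2 to compound 3 (the limit leaves the size open). The estimate for compound 3 in this assay is 100000 nM, with a range from 30000 nM to 300000 nM.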

Compound 3, half-maximal inhibitory concentration: > 100000 nM
Compound 3: no number, only a limit; the forecaster's own chance of this, stated with the estimate: 70%; the middle value sits exactly at the limit.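

In this assay compound 3 gives only a limit, > 100000 nM. For the compounds shown here, no step among compound 1, compound 2 and compound 3 can therefore be read. These compounds leave open whether any group on the amide-type nitrogen changes the read-out, as none of them yields a number.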